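Shifting the Ring Double Bond of Compound 2

The compounds below may be only part of what the source reports. "The series", "measured", "known", "first", "only" and "open" are said of these compounds alone.

Three measured compounds share one core and differ only in how two chain stereocentres are drawn: compound 1 `C=C1[C@H](C)CCC[C@]1(C)CC/C(C)=C/CC1=C(O)C(=O)C=C(N[C@@H](C(=O)O)[C@H](C)O)C1=O`, compound 2 `C=C1[C@H](C)CCC[C@]1(C)CC/C(C)=C/CC1=C(O)C(=O)C=C(N[C@H](C(=O)O)[C@H](C)O)C1=O` and compound 3 `C=C1[C@H](C)CCC[C@]1(C)CC/C(C)=C/CC1=C(O)C(=O)C=C(N[C@@H](C(=O)O)[C@@H](C)O)C1=O`. Each was tested in an ADME assay on KB cells (Homo sapiens) for cytotoxicity, with a stated time of 48 h; on this read-out lower numbers stand for stronger inhibition and higher numbers for weaker inhibition. In this assay compound 1 reaches only the limit > 10 ug/mL, which is a limit of the assay and not a number. Compound 2 likewise gives only the limit > 10 ug/mL. Compound 3 also stops at the limit > 10 ug/mL. So compound 2 stands at the same limit as its two stereoisomers, and none of the three can be ranked. The steps between them, a step that the two limits leave unreadable from compound 1 to compound 2, a step that the two limits leave unreadable from compound 1 to compound 3 and a step that the two limits leave unreadable from compound 2 to compound 3, cannot be read because of the limit of > 10 ug/mL in this assay, at which 3 of the 3 values shown sit; the comparisons rest on (the fact that compounds 1 and 2 differ only in the configuration as drawn), the fact that compounds 1 and 3 differ only in the configuration as drawn and the fact that compounds 2 and 3 differ only in the configuration as drawn alone.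

Compound 4 `CC1=CCC[C@](C)(CC/C(C)=C/CC2=C(O)C(=O)C=C(N[C@H](C(=O)O)[C@H](C)O)C2=O)[C@@H]1C` is not yet measured. It differs from compound 2 in one ring group: a group of 9 heavy atoms (9 carbon; one six-membered non-aromatic ring of carbon only) in place of a group of 9 heavy atoms (9 carbon; one six-membered non-aromatic ring of carbon only), on a saturated chain carbon, two bonds along the chain from a double-bonded chain carbon. Among the compounds with values here, none of the measured steps bears on this change; all of them concern configuration only, and their sizes are unreadable. With no readable step to lean on, no shift beyond the scatter is expected. The expected step is a step that the limit leaves unreadable from compound 2 to compound 4, essentially flat. Compound 4 is estimated at 15 ug/mL, expected within 5 ug/mL to 50 ug/mL, and most likely again only a limit.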

Compound 4, half-maximal inhibitory concentration: > 10 ug/mL
Compound 4 was reported as a limit; the forecaster's own chance of this, stated with the estimate: 75%; the middle value does not contradict the limit.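

The step between compound 2 and compound 4 cannot be read, because both results are limits of the assay and not numbers: the limit of > 10 ug/mL in this assay, at which 4 of the 4 values shown sit.

The compounds shown leave open how strong each of the four really is, and whether the shifted ring double bond or the drawn configuration changes the result at all in this assay.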